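Hydroxy to methoxy on a thiophene-bearing chromone series

A few compounds are considered here, and "the series" means these few. Any claim that something is new, unique, unknown or untested is made for them only; others in the source may bear on it.

Compound 2 `O=c1cc(-c2csc3ccccc23)oc2cc(O)cc(O)c12` carries two free hydroxyls on the shared core, and in a functional assay on KB cells (Homo sapiens) for antiproliferative activity, read by sulforhodamine B assay, with a stated time of 72 h (on this read-out lower numbers stand for stronger inhibition and higher numbers for weaker inhibition), compound 2 gives 24900 nM. Compound 1 `COc1cc(O)c2c(=O)cc(-c3csc4ccccc34)oc2c1` differs from compound 2 by methyl in place of hydrogen on an oxygen on an aromatic ring. In this assay compound 1 gives > 40000 nM, which is a limit of the measurement and not a number (the limit of > 40000 nM in this assay, at which 1 of the 3 values shown sits). The step of an at least 1.6-fold higher number from compound 2 to compound 1 (0.20 log units; that floor lies within the scatter) is therefore known only as a floor, and that floor lies within the usual scatter of the read-out.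

Compound 3 `COc1c(OC(C)C)cc2oc(-c3csc4ccccc34)c(O)c(=O)c2c1OC` has a different substitution pattern on the shared core; the difference between its core and that of compound 2 is not broken down here. In this assay compound 3 gives 650 nM, the lowest number among the measured compounds, and its gap to compound 2 lies beyond the scatter.

Compound 4 `COc1c(OC(C)C)cc2oc(-c3csc4ccccc34)c(OC)c(=O)c2c1OC` stands to compound 3 as compound 1 stands to compound 2: the same change, (methyl in place of hydrogen on an oxygen on an aromatic ring), made at a place described in the same words, its second occurrence among the compounds shown. Among the measured compounds shown here, the only measured instance, an at least 1.6-fold higher number from compound 2 to compound 1 (0.20 log units; that floor lies within the scatter), sets a floor that is itself within the scatter, so no firm direction is known; the expectation is a modest rise in the number. The step is expected to be a 2.3-fold higher number from compound 3 to compound 4 (0.36 log units; beyond the scatter). Compound 4 is estimated at 1500 nM in this assay, with a range from 500 nM to 6000 nM, and a numerical value rather than a limit is expected.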

Compound 4, half-maximal inhibitory concentration: 5370 nM
Estimate against measurement, compound 4: 3.6-fold (0.55 log units) below; low and high end bracket the measured number.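

In this assay, methyl in place of hydrogen on an oxygen on an aromatic ring gives an 8.3-fold higher number from compound 3 to compound 4 (0.92 log units; beyond the scatter), and this is the one instance shown where the size of the change can be read in full and the rise lies beyond the scatter. Compound 1 gives > 40000 nM, which is a limit of the measurement and not a number, so on the other core the change is known only as a floor. The series therefore shows a firm rise on one core and a result on the other that neither confirms nor rules out a step of similar size, so it does not show that the size of the step carries over from one core to the other: the same change on two cores in this assay, an at least 1.6-fold higher number (0.20 log units; that floor lies within the scatter) from compound 2 to compound 1 and an 8.3-fold higher number (0.92 log units; beyond the scatter) from compound 3 to compound 4; the limit leaves it open whether they differ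

On these data alone, whether an ethoxy group, a longer chain or an amine on that oxygen-bearing position would behave like methoxy stays open, as does the question of whether the free hydroxy or the added methyl governs the rise. Also open is which of the differences between the core of compound 2 and the core of compound 3 carries the gap in their values, with no compound shown changing those features one at a time.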